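Azetidin-1-yl in Place of (tert-Butyl)amino on a Carbonyl Carbon

A few compounds are considered here, and "the series" means these few. Any claim that something is new, unique, unknown or untested is made for them only; others in the source may bear on it.

In a functional assay on BT-474 cells (Homo sapiens) for antiproliferative activity, read by sulforhodamine B assay, with a stated time of 4 days (a higher number here means a weaker inhibitor of growth, a lower number a stronger inhibitor of growth), compound 1 (`COc1cc(Cl)c(-c2nc(SCC(=O)NC(C)(C)C)nc3[nH]cc(C#N)c23)cc1O`) gives 128 nM and compound 2 (`COc1cc(Cl)c(-c2nc(SCC(=O)NC(C)(C)C)nc3[nH]cc(C#N)c23)cc1OC`) gives 121 nM, so the two stand level. For the measured compounds named here, the only measured step, a 1.1-fold lower number from compound 1 to compound 2 (0.02 log units; within the scatter), concerns an oxygen on an aromatic ring. Compound 3 (`COc1cc(Cl)c(-c2nc(SCC(=O)N3CCC3)nc3[nH]cc(C#N)c23)cc1OC`) instead carries azetidin-1-yl in place of (tert-butyl)amino on a carbonyl carbon. Going by the values given here, no measured step touches that place, so the data give little guidance, and only a modest loss of growth inhibition is tentatively expected. The expected change is a 2.1-fold higher number from compound 2 to compound 3 (0.32 log units; beyond the scatter). For compound 3, the estimated value is 250 nM, within an expected range of 70 nM to 900 nM.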

Compound 3, concentration for 50% growth inhibition: 31 nM
Compound 3: middle estimate off by 8.1-fold (0.91 log units), on the high side; the whole stated range lies above it.
By their numbers in this assay, from the lowest: compound 3; then compounds 2 and 1 (each within the scatter of the next).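

In this assay, for the compounds shown here, azetidin-1-yl in place of (tert-butyl)amino on a carbonyl carbon gives a 3.9-fold lower number from compound 2 to compound 3 (0.59 log units; beyond the scatter), so this position, which no earlier step touched, responds to the group placed on it. Going by these compounds alone, the only earlier step, at the oxygen on the aromatic ring, stayed within the scatter, whereas this one lies beyond it. Nothing available accounts for the lower number.

The compounds shown leave open whether the loss of the amide hydrogen or the four-membered ring itself goes with this change. A dimethylamino or pyrrolidin-1-yl group on the same carbonyl carbon would separate the two.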